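This account rests on a few compounds, and the source may have more. Where it says the series, first, only, none or still open, it means among the compounds named here.

Of the compounds shown here, three have been tested in a functional assay on the whole organism for inhibition, with Echinochloa esculenta as the target; a lower number here means a stronger inhibitor, a higher number a weaker inhibitor. Compound 1, `COC(=O)CSc1cc(/N=c2\sc(=S)n3n2CCCC3)c(F)cc1Cl`, gives 269 nM in this assay, which places it second highest of the three numbers measured. Compound 3, `Fc1cc(Cl)ccc1-n1c(=S)n2n(c1=S)CCCC2`, gives the lower value 91.2 nM in this assay, and the gap between compound 3 and compound 1 lies beyond the usual scatter of repeated measurements. Going by the values given here, compound 2, `S=c1s/c(=N\c2ccc(OCc3ccc(Cl)cc3)cc2)n2n1CCCC2`, gives 5500 nM in this assay, the highest of the three numbers and the one furthest from compound 1.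

Compound 4, `CC(C)Oc1cc(/N=c2\sc(=S)n3n2CCCC3)c(F)cc1Cl`, has not yet been measured in this assay. It differs from compound 1 in one place: isopropoxy in place of ((methoxycarbonyl)methyl)sulfanyl on an aromatic carbon. Among the compounds with values here, no pair of measured compounds that differ in only one place is available, so the size of this step cannot be read from a precedent and has to be expected instead. The measured compounds show that the number can move a good deal, yet for this particular change no direction is indicated, so a modest step is expected, no larger than the difference between compound 1 and compound 3. Compound 4 is expected to give about 250 nM in this assay, within a range from 80 nM to 800 nM. The expected step of a 1.1-fold lower number from compound 1 to compound 4 (0.03 log units; within the scatter) is accordingly small and of uncertain direction.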

Compound 4, half-maximal inhibitory concentration: 28.2 nM
Compound 4: the middle estimate sits 8.9-fold (0.95 log units) above what was measured, outside the stated range (below it).
By their numbers in this assay, from the lowest: compound 4; then compound 3; then compound 1; then compound 2.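

In this assay the position ortho to a chloro group and para to a fluoro group proves sensitive to its substituent: replacing ((methoxycarbonyl)methyl)sulfanyl with isopropoxy gives a 9.5-fold lower number from compound 1 to compound 4 (0.98 log units; beyond the scatter), the first step seen between measured compounds that differ in one place. The departing group has 6 heavy atoms and 3 hydrogen-bond acceptors, whereas the entering group has 4 heavy atoms and 1 hydrogen-bond acceptor, so compound 4 shows that the ((methoxycarbonyl)methyl)sulfanyl group is not required for a low number on this scaffold. Nothing measured here explains why the number falls with this change.

Sulfur and oxygen change together with the rest of the group in this single step; the pair therefore cannot show whether the linking atom or the chain attached to it matters more. Going by these compounds, how an isopropylsulfanyl group, a smaller methoxy group or a carboxylic acid at this position would read in this assay remains open.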